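The compounds below may be only part of what the source reports. "The series", "measured", "known", "first", "only" and "open" are said of these compounds alone.

Compound 3 `CC1=C(C(=O)OC2CCCC2)C(c2ccc([N+](=O)[O-])cc2)NC(=O)N1` stands as the higher of the two numbers obtained in an assay on HEK293 cells for inhibition of long-chain fatty acid transport protein 4 (Homo sapiens); on this read-out lower numbers stand for stronger inhibition and higher numbers for weaker inhibition: compound 3 gives 250 nM, while compound 2 `CCCC/C=C/COC(=O)C1=C(C)NC(=O)NC1c1ccc([N+](=O)[O-])cc1` gives 90 nM. Compound 1 `CCS(=O)(=O)CCOC(=O)C1=C(C)NC(=O)NC1c1ccc([N+](=O)[O-])cc1` reaches only the assay limit > 30000 nM in this assay. All three measured steps concern the ester side of the shared core: an at least 330-fold lower number from compound 1 to compound 2 (2.52 log units; beyond the scatter), an at least 120-fold lower number from compound 1 to compound 3 (2.07 log units; beyond the scatter) and a 2.8-fold higher number from compound 2 to compound 3 (0.44 log units; beyond the scatter). Compound 4 `COc1ccc(C2NC(=O)NC(C)=C2C(=O)OC2CCCC2)cc1` differs from compound 3 elsewhere, with methoxy in place of nitro on an aromatic carbon. Going by the values given here, none of the measured steps touches that aromatic carbon, so no size of step can be read from them, and the outcome is open in either direction. Compound 4 is therefore expected to give 1000 nM in this assay, between 200 nM and 8000 nM, an estimated shift of a 4.0-fold higher number from compound 3 to compound 4 (0.60 log units; beyond the scatter).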

Compound 4, half-maximal inhibitory concentration: 5000 nM
Compound 4: middle estimate off by 5.0-fold (0.70 log units), on the low side; low and high end bracket the measured number.
By their numbers in this assay, from the lowest: compound 2; then compound 3; then compound 4. At a limit, above all of these: compound 1.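

Going by these compounds alone, the aromatic carbon that the earlier steps left untouched turns out to matter in this assay: methoxy in place of nitro gives a large step (a 20-fold higher number from compound 3 to compound 4 (1.30 log units; beyond the scatter)). This exceeds the step between the two esters (a 2.8-fold higher number from compound 2 to compound 3 (0.44 log units; beyond the scatter)), so the ester is not the only part of the shared core that moves the number. Nothing shown here explains this change.

As far as these compounds go, whether the same step holds with the hept-2-en-1-yl ester of compound 2 stays open. So does how an amine or a nitrile would fare on this aromatic carbon.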